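Benzyl-substituted oxadiazolone series: ring substituent survey

The source may report more compounds than this note shows. Statements on the series, on what has been measured and on what is new or still open speak of the compounds shown alone.

Measured compounds:
compound 1 `COc1nn(Cc2ccccc2)c(=O)o1` — "not active" (no number reported)
compound 2 `COc1nn(Cc2cccc3ccccc23)c(=O)o1` — 35%
compound 3 `COc1nn(Cc2ccc([N+](=O)[O-])cc2)c(=O)o1` — 18%

Notes. In an assay on COS-7 cells for inhibition of Fatty-acid amide hydrolase 1 (Homo sapiens), read by scintillation counting, with a stated time of 10 min, tested at 10 uM (a higher number here means more inhibition at the concentration tested (going by the name of the read-out), a lower number less inhibition), compound 1 is recorded as "not active" (no number reported); no number is given for it. Compound 2 carries a larger bicyclic aromatic in place of the phenyl and gives 35% in this assay. Compound 3, with a nitro group on the phenyl, gives 18%. Both substituted analogues show some inhibition at the test concentration, whereas the unsubstituted parent shows none that could be quantified.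

Compound 4 `COc1nn(Cc2ccccc2NC(C)=O)c(=O)o1` is the next analogue. It differs from compound 1 by acetamido in place of hydrogen on an aromatic carbon. Among the compounds with values here, no measured pair in the set isolates this change, so its size cannot be read from an existing step. Going by compounds 2 and 3, a substituent on the phenyl has so far lifted the read-out from the unquantified result of compound 1 into the low-to-moderate range, and a step of that kind, upward but modest, is expected for compound 4 in this assay. Compound 4 is estimated at 18%, with a range of 0% to 40%.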

Compound 4, a percentage reported as inhibition, at one concentration (the size of the read-out at that concentration, not a potency): 11%
Compound 4: middle estimate off by 7 percentage points, on the high side, within the range that was stated.
By their numbers in this assay, from the lowest: compounds 4 and 3 (each within the scatter of the next); then compound 2.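

No new step can be read: compound 1 carries no number, so its difference from compound 4 has no size. The compounds shown leave open how large the change from hydrogen to acetamido is on its own. No evidence bears on this result.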